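The source may report more compounds than this note shows. Statements on the series, on what has been measured and on what is new or still open speak of the compounds shown alone.

Measured so far in a functional assay on L02 cells (Homo sapiens) for inhibition, read by Griess assay, with stated times of 1 h and 24 h; on this read-out lower numbers stand for stronger inhibition and higher numbers for weaker inhibition:

- Compound 1 `CCCc1nn(C)c2c(NC3CC3)nc(/C=C/c3nc(C)c(C)nc3C)nc12`: 706000 nM
- Compound 2 `CCCc1nn(C)c2c(NC(C)C)nc(/C=C/c3ccc[n+]([O-])c3)nc12`: 324000 nM
- Compound 3 `CCCCNc1nc(/C=C/c2ccccc2)nc2ccsc12`: > 1000000 nM (a limit, not a number)

Compound 3 has no number on this read-out and sits at the limit of > 1000000 nM in this assay, at which 1 of the 3 values shown sits. For the measured compounds named here, its place relative to compound 1 and compound 2 therefore cannot be given as a step, and no measured pair differs in one place only.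

The next compound is compound 4 `Clc1ccccc1CNc1nc(/C=C/c2ccccc2)nc2ccsc12`, which keeps the core of compound 3 and changes the amine substituent. The difference is 2-chlorophenyl in place of propyl on a saturated chain carbon bound to a nitrogen on an aromatic ring. Cut one bond further out, this reads butyl to 2-chlorobenzyl.

Going by the values given here, no measured step isolates this change, so the expectation is a loose one. Compound 1 gives 706000 nM and compound 2 gives 324000 nM, so numbers in this series have so far stayed in the same high range, and a large gain in this assay is not expected. A modest move toward lower numbers is expected, possibly none beyond the scatter, and a second limit reading remains quite possible. The expected change is an at least 1.6-fold lower number from compound 3 to compound 4 (0.22 log units; that floor lies within the scatter).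

The estimate for compound 4 is 600000 nM, with an expected range of 200000 nM to 1000000 nM.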

Compound 4, half-maximal inhibitory concentration: > 1000000 nM
Compound 4 was reported as a limit; the forecaster's own chance of this, stated with the estimate: 45%; at least 1.6-fold (0.22 log units) between middle value and limit.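

Compound 3 and compound 4 both stand as limits, not numbers, in this assay, so no step can be read for the change from butyl to 2-chlorobenzyl: the limit of > 1000000 nM in this assay, at which 2 of the 4 values shown sit. The compounds shown leave open whether this change on the amine moves the read-out at all.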